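Compound 3 to compound 4: benzyl swapped for 4-nitrophenyl

A few compounds are considered here, and "the series" means these few. Any claim that something is new, unique, unknown or untested is made for them only; others in the source may bear on it.

Values in a functional assay on RS4-11 cells (Homo sapiens) for inhibition, read by CCK-8 assay, with a stated time of 48 h; on this read-out higher numbers stand for weaker inhibition and lower numbers for stronger inhibition:
- compound 1 `O=S(=O)(NCCNC(=S)Nc1cc(C(F)(F)F)cc(C(F)(F)F)c1)c1ccc(-c2ccccc2OCc2cccc(O)c2)s1`: 12000 nM
- compound 2 `O=S(=O)(NCCNC(=S)Nc1cc(C(F)(F)F)cc(C(F)(F)F)c1)c1ccc(-c2ccccc2O[C@H]2CC[C@@H](O)CC2)s1`: 6300 nM
- compound 3 `O=S(=O)(NCCNC(=S)Nc1cc(C(F)(F)F)cc(C(F)(F)F)c1)c1ccc(-c2ccccc2OCc2ccccc2)s1`: > 50000 nM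

From the compounds shown here alone, for compound 3 this figure is a limit of the assay and not a number, so its true position is unknown. The next structure is compound 4 `O=[N+]([O-])c1ccc(Oc2ccccc2-c2ccc(S(=O)(=O)NCCNC(=S)Nc3cc(C(F)(F)F)cc(C(F)(F)F)c3)s2)cc1`, with 4-nitrophenyl in place of benzyl on an oxygen on an aromatic ring.

Within the data shown here, two measured steps bear on this change: an at least 4.1-fold higher number from compound 1 to compound 3 (0.61 log units; beyond the scatter) and an at least 7.9-fold higher number from compound 2 to compound 3 (0.89 log units; beyond the scatter). Both lead to compound 3, which has no hydroxy on the group on that oxygen. Compound 4 also lacks one, so it is expected to stay close to compound 3 in this assay, with no step beyond the scatter. Among the measured compounds shown here, no measured step covers 4-nitrophenyl itself, so the estimate stays wide. The estimated step is an at least 1.2-fold lower number from compound 3 to compound 4 (0.09 log units; that floor lies within the scatter). For compound 4 the expected value is 40000 nM, with an estimated range of 12000 nM to 50000 nM.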

Compound 4, half-maximal inhibitory concentration: 6300 nM
Compound 4: middle estimate off by 6.3-fold (0.80 log units), on the high side; the measured number lies below the stated range.
By their numbers in this assay, from the lowest: compounds 2, 4 and 1 (each within the scatter of the next). At a limit, above all of these: compound 3.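

In this assay, among these compounds, the earlier compounds gave a measured number on this oxygen only with a hydroxy on the group, yet compound 4 has no hydroxy and still gives one, with an at least 7.9-fold lower number from compound 3 to compound 4 (0.89 log units; beyond the scatter). The figure for compound 3 is a limit of the assay, so this step is only a floor: the limit of > 50000 nM in this assay, at which 1 of the 4 values shown sits. The 4-nitrophenyl group sits level with both hydroxy-bearing groups, with no change at the digits printed from compound 2 to compound 4 (within the scatter) and a 1.9-fold lower number from compound 1 to compound 4 (0.28 log units; within the scatter), so across compound 1, compound 2 and compound 4 a hydroxy is not required for a measured number.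

Compound 4 departs from compound 3 both in the nitro group and in going from benzyloxy to a phenoxy link, and the shown compounds do not separate these two changes. Also open, from the compounds shown here alone, is how a plain phenyl on this oxygen, or a phenyl carrying an amine or a carboxylic acid in place of the nitro group, would read.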